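The source may report more compounds than this note shows. Statements on the series, on what has been measured and on what is new or still open speak of the compounds shown alone.

Working notes on the series in an ADME assay on microsomes from liver (Mus musculus) for metabolic stability, read by LC-MS, tested at 1 uM; on this read-out higher numbers stand for fast clearance and lower numbers for slow clearance. Compound 1 `CCOC(=O)C1=C(C)N/C(=C/c2cc(C)n(-c3ccc(Br)cc3)c2C)C1=O` gives 62 mL.min-1.g-1; compound 2 `CCOC(=O)C1=C(C)N/C(=C/c2cc(C)n(-c3ccc(N(C)C)cc3)c2C)C1=O` gives 56 mL.min-1.g-1; compound 3 `CCOC(=O)C1=C(C)N/C(=C/c2cc(C)n(-c3ccc(SC)cc3)c2C)C1=O` gives 66 mL.min-1.g-1. Compound 3 sits within the scatter of both others: a 1.1-fold higher number from compound 1 to compound 3 (0.03 log units; within the scatter) and a 1.2-fold higher number from compound 2 to compound 3 (0.07 log units; within the scatter), and also a 1.1-fold lower number from compound 1 to compound 2 (0.04 log units; within the scatter). Compound 4 `CCOC(=O)C1=C(C)N/C(=C/c2cc(C)n(-c3ccncc3)c2C)C1=O` differs from compound 3 by pyridin-4-yl in place of 4-(methylsulfanyl)phenyl on an aromatic nitrogen. Within the data shown here, no measured step touches this aromatic nitrogen substituent beyond its para position, yet all three swaps there left this assay unchanged, so for compound 4 no step beyond the scatter is expected, and the expected change is a 1.1-fold lower number from compound 3 to compound 4 (0.04 log units; within the scatter). Compound 4 is therefore estimated at 60 mL.min-1.g-1, in the range 30 mL.min-1.g-1 to 120 mL.min-1.g-1, pending the measurement.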

Compound 4, intrinsic clearance in microsomes: 61 mL.min-1.g-1
Estimate against measurement, compound 4: 1.0-fold (0.01 log units) below, within the range that was stated.
By their numbers in this assay, from the lowest: compounds 2, 4, 1 and 3 (each within the scatter of the next).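

Earlier steps changed only the group carried on the phenyl ring, whereas here the carbon-only aromatic ring itself gives way to pyridin-4-yl, and in this assay all three steps stay within the scatter (a 1.1-fold lower number from compound 3 to compound 4 (0.03 log units; within the scatter)) (a 1.1-fold higher number from compound 2 to compound 4 (0.04 log units; within the scatter)) (a 1.0-fold lower number from compound 1 to compound 4 (0.01 log units; within the scatter)). The aromatic nitrogen of the shared core therefore accepts a ring with a hetero atom, as well as 4-substituted phenyl groups, without a readable change in this read-out. No measurement at hand gives a reason for this flat response. From the compounds shown here alone, whether a saturated amine ring or a carboxylic acid at this aromatic nitrogen would move the number remains open. So does the effect of any change elsewhere on the shared core.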